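Replacing a Methoxyphenyl Group with a Pyrazinyl Group

The source may hold more compounds than are shown below. What is called first, only, known or untested is meant among the compounds shown, and "the series" means these compounds.

The measured compounds are compound 1 `Nc1ccccc1NC(=O)c1ccc(CSC(=S)N2CCc3cc([N+](=O)[O-])ccc32)cc1` with 29.5%, compound 2 `COc1ccc(N2CCN(C(=S)SCc3ccc(C(=O)Nc4ccccc4N)cc3)CC2)cc1` with 35.9%, and compound 3 `Nc1ccccc1NC(=O)c1ccc(CSC(=S)N2CCc3cc(Cl)ccc32)cc1` with 82.3%, all in a functional assay on A-375 cells (Homo sapiens) for antiproliferative activity, read by CCK-8 assay, with a stated time of 72 h, tested at 8 uM; a higher number here means a stronger effect of the compound at the concentration tested, a lower number a weaker effect.

Compound 2 sits second of the three numbers. Compound 1 is its nearest neighbour, and the two values lie within the usual scatter of each other, so no order between them can be read. Compound 3 lies furthest from compound 2, beyond the scatter. Among the compounds with values here, the one step measured on a single change, a number 52.8 percentage points higher from compound 1 to compound 3 (beyond the scatter), was large, but it concerns a chloro in place of nitro on an aromatic carbon, a different part of the shared core.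

Compound 4 `Nc1ccccc1NC(=O)c1ccc(CSC(=S)N2CCN(c3cnccn3)CC2)cc1` is not yet measured. It differs from compound 2 by pyrazin-2-yl in place of 4-methoxyphenyl on an amine nitrogen in a ring. Within the data shown here, no measured step touches this place, so there is no basis for expecting a change beyond the scatter in this assay. Compound 4 is therefore estimated at 33% with a range from 15% to 55%. The expected step is a number 2.9 percentage points lower from compound 2 to compound 4 (within the scatter), which is held near zero.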

Compound 4, a percentage reported as inhibition, at one concentration (the size of the read-out at that concentration, not a potency): 85.8%
For compound 4 the middle estimate is 52.8 percentage points below the measured one; the whole stated range lies below it.
By their numbers in this assay, from the lowest: compounds 1 and 2 (each within the scatter of the next); then compounds 3 and 4 (each within the scatter of the next).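

In this assay the swap of 4-methoxyphenyl for pyrazin-2-yl on the amine nitrogen in a ring gives a number 49.9 percentage points higher from compound 2 to compound 4 (beyond the scatter) and so shows that this position, untouched by any earlier step, is not a silent one. Within the data shown here, until now the only step read on a single change was a number 52.8 percentage points higher from compound 1 to compound 3 (beyond the scatter) in a different part of the shared core, and the new step shows that a change at this second place can also be large. Nothing at hand explains why this exchange of rings carries so large a step.

The single change removes the methoxy group and also brings ring nitrogens in, so the compounds shown cannot tell these two parts apart. A plain phenyl or a pyridin-2-yl group at this position would begin to separate them.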